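Swapping a Phenyl Ether for a Methylpyridyl Ether

The source may report more compounds than this note shows. Statements on the series, on what has been measured and on what is new or still open speak of the compounds shown alone.

Compound 2 `CC(C)CCn1ccc(-c2ccc(Oc3ccccc3)cc2)c(C#N)c1=O` carries a phenyl attached through an oxygen on an aromatic ring. In a functional assay on CHO cells for positive allosteric modulation of metabotropic glutamate receptor 2 (Homo sapiens), read by scintillation counting and GTPgammaS binding, with a stated time of 30 min (on this read-out higher numbers stand for larger maximal responses and lower numbers for smaller maximal responses), compound 2 gives 188%, the lowest of the three numbers gathered here. Compound 1 `COc1ccc(-c2ccn(CCC(C)C)c(=O)c2C#N)cc1OC` reaches 242% in this assay, and compound 3 `CC(C)CCn1ccc(-c2ccc(NC3CCOCC3)c(Cl)c2)c(C#N)c1=O` reaches 247%; each of these exceeds compound 2 by more than the usual scatter. Compound 4 `Cc1ncccc1Oc1ccc(-c2ccn(CCC(C)C)c(=O)c2C#N)cc1` differs from compound 2 in one place: 2-methylpyridin-3-yl in place of phenyl on an oxygen on an aromatic ring. For the measured compounds named here, no measured pair shows this exchange, so its effect is unknown. The step of a number 17 percentage points higher from compound 2 to compound 4 (beyond the scatter) in this assay is expected to be a modest rise, within or at the edge of the scatter. The estimated maximal response of compound 4 is 205%, within a range from 150% to 260%.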

Compound 4, largest response reached (Emax), in percent of the reference or control that the assay uses: 256%
Compound 4: the middle estimate sits 51 percentage points below what was measured; the measured number falls inside the stated range.
By their numbers in this assay, from the lowest: compound 2; then compounds 1, 3 and 4 (each within the scatter of the next, the first and the last beyond it).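

For the compounds shown here, this is the first pair here that differs in one place. In this assay, putting 2-methylpyridin-3-yl in place of phenyl on an oxygen on an aromatic ring gives a number 68 percentage points higher from compound 2 to compound 4 (beyond the scatter) as a large step, so the maximal response depends on which ring sits on this oxygen. No available information bears on why the response rises.

The new ring brings both a ring nitrogen and a methyl group, and this single step cannot separate them. Pyridin-3-yl and 2-methylphenyl on the same oxygen would each carry only one of the two.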